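From chloro to 2-isopropylphenoxy: notes on compound 3

The source may report more compounds than this note shows. Statements on the series, on what has been measured and on what is new or still open speak of the compounds shown alone.

Compound 1 `COc1cc(OC)c(/C=C/C(=O)/C=C/c2cc3ccccc3nc2Cl)c(OC)c1` is the starting point for this step. In a functional assay on PC-3 cells (Homo sapiens) for cytotoxicity, read by MTT assay, with a stated time of 48 h (on this read-out higher numbers stand for weaker inhibition and lower numbers for stronger inhibition), compound 1 gives > 10000 nM, which is a limit of the assay and not a number.

Compound 2 `COc1cc(OC)c(OC)cc1/C=C/C(=O)/C=C/c1cc2ccccc2nc1Oc1ccccc1` carries an aryloxy group where compound 1 carries chloro, but it also differs in the arrangement of its methoxy groups. In this assay compound 2 gives 7290 nM. Going by the values given here, no clean single-change step is therefore available from the measured pair.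

Compound 3 `COc1cc(OC)c(/C=C/C(=O)/C=C/c2cc3ccccc3nc2Oc2ccccc2C(C)C)c(OC)c1` keeps the core of compound 1 and has 2-isopropylphenoxy in place of chloro on an aromatic carbon, next to the ring nitrogen: 2-isopropylphenoxy in place of chloro on an aromatic carbon.

The reading for compound 2 of 7290 nM is the only support for expecting a measurable number from an aryloxy member of the series. The expectation is therefore a modest shift towards stronger inhibition, and a second limit reading remains possible. The expected size of the change is an at least 2.2-fold lower number from compound 1 to compound 3 (0.34 log units; beyond the scatter).

For compound 3 the estimated value is 4500 nM, with an expected range of 1200 nM to 14000 nM.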

Compound 3, half-maximal inhibitory concentration: > 10000 nM
Compound 3: a limit, no number; the forecaster's own chance of this, stated with the estimate: 25%; at least 2.2-fold (0.34 log units) between middle value and limit.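

In this assay compound 3 gives > 10000 nM and this is a limit of the assay, not a number. Going by these compounds alone, no step from compound 1 to compound 3 can be read, with both values being limits: the limit of > 10000 nM in this assay, at which 2 of the 3 values shown sit.

From the compounds shown here alone, whether 2-isopropylphenoxy in place of chloro changes the reading in this assay at all stays open.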